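Working notes: compound 2 and its demethyl analogue compound 4

This account rests on a few compounds, and the source may have more. Where it says the series, first, only, none or still open, it means among the compounds named here.

In a functional assay on MIA PaCa-2 cells (Homo sapiens) for inhibition, read by MTT assay, with a stated time of 72 h (a lower number here means a stronger inhibitor, a higher number a weaker inhibitor), compound 1 `O=C(Nc1cccc2cccnc12)c1cnc(Cl)cn1` gives 7000 nM. Compound 2 `Cc1cnc(C(=O)Nc2ccc(Br)c3cccnc23)cn1` gives 2200 nM in this assay, the lower of the two numbers in hand; the gap between compound 2 and compound 1 lies beyond the usual scatter. Compound 3 `CN(C)Cc1ccc2cccc(NC(=O)c3cnccn3)c2n1` reaches only a limit in this assay, > 10000 nM. That limit is the limit of > 10000 nM in this assay, at which 1 of the 3 values shown sits.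

Compound 4 `O=C(Nc1ccc(Br)c2cccnc12)c1cnccn1` is not yet measured. It differs from compound 2 by hydrogen in place of methyl on an aromatic carbon; in words, hydrogen in place of methyl on an aromatic carbon, the 5-methylpyrazin-2-yl group becoming pyrazin-2-yl. Among the measured compounds shown here, no measured pair shows this change on its own, so its size is not known. Compound 1 and compound 3 carry other differences as well and cannot settle the point.

The step from compound 2 to compound 4 in this assay is expected to be a 1.6-fold higher number from compound 2 to compound 4 (0.20 log units; within the scatter), a modest loss that may not exceed the scatter. Compound 4 is therefore estimated at 3500 nM, with a range from 1200 nM to 10000 nM in this assay.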

Compound 4, half-maximal inhibitory concentration: 750 nM
Compound 4: the middle estimate sits 4.7-fold (0.67 log units) above what was measured; the whole stated range lies above it.
By their numbers in this assay, from the lowest: compound 4; then compound 2; then compound 1. At a limit, above all of these: compound 3.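

In this assay, among the compounds shown here, the change from 5-methylpyrazin-2-yl to pyrazin-2-yl gives a 2.9-fold lower number from compound 2 to compound 4 (0.47 log units; beyond the scatter), the only single-place comparison so far. The methyl group on this aromatic carbon is therefore not needed for activity in this pair, and removing it gives the lower number. No measurement in hand bears on why the step runs in this direction.

Still open, on these data alone, is whether any other group on this carbon, such as methoxy, an amine, a carboxylic acid or a longer chain like propyl, would give a lower or a higher number than hydrogen. For the compounds shown here, also open is whether the same step would hold on a compound without the bromine, as only this one pair has been read.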